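The source may hold more compounds than are shown below. What is called first, only, known or untested is meant among the compounds shown, and "the series" means these compounds.

Three compounds share one core and differ only in the group carried on the amide-type nitrogen. Compound 1 `Cc1nc(N)sc1CCCN/C(N)=N/C(=O)N[C@H](C)c1ccccc1` gives 0.34 in a functional assay on HEK293T cells for agonist activity at histamine H2 receptor (Homo sapiens), read by beta-arrestin recruitment (a lower number here means a smaller maximal response, a higher number a larger maximal response), and compound 2 `Cc1nc(N)sc1CCCN/C(N)=N/C(=O)N[C@@H](C)c1ccccc1` gives 0.46; the rise of a number 0.12 higher from compound 1 to compound 2 (beyond the scatter) rests on (the fact that compounds 1 and 2 differ only in the configuration as drawn). Compound 3 `Cc1nc(N)sc1CCCN/C(N)=N/C(=O)Nc1ccccc1`, with phenyl on that nitrogen, gives 0.25, the lowest of the three numbers: the step a number 0.090 lower from compound 1 to compound 3 (within the scatter) stays within the scatter, while a number 0.21 lower from compound 2 to compound 3 (beyond the scatter) goes beyond it.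

Compound 4 `Cc1nc(N)sc1CCCN/C(N)=N/C(=O)NC(C)c1ccco1` changes that phenyl: 1-(furan-2-yl)ethyl in place of phenyl on an amide-type nitrogen. The two measured steps that bear on this, a number 0.090 lower from compound 1 to compound 3 (within the scatter) and a number 0.21 lower from compound 2 to compound 3 (beyond the scatter), ran the other way, from 1-phenylethyl to phenyl, and lowered the number by a modest amount at most. Reversing that change, with a furan-2-yl ring in place of the phenyl of the 1-phenylethyl group and no configuration fixed, points to a modest rise that is expected to land between the two measured partners. Compound 4 is therefore expected to give 0.38, within a range of 0.27 to 0.5. The expected step is a number 0.13 higher from compound 3 to compound 4 (beyond the scatter).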

Compound 4, intrinsic activity: the largest response reached, as a fraction of the reference agonist's: 0.25
The estimate for compound 4 lay 0.13 above the measured number; measured number below the stated range.
By their numbers in this assay, from the lowest: compounds 3, 4 and 1 (each within the scatter of the next); then compound 2.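

Replacing phenyl with 1-(furan-2-yl)ethyl on the amide-type nitrogen leaves the maximal response unresolved from that of the phenyl compound, with (no change at the digits printed from compound 3 to compound 4 (within the scatter)). Set against the 1-phenylethyl pair, the furan-2-yl compound separates from only one partner: a number 0.090 lower from compound 1 to compound 4 (within the scatter) stays within the scatter, while a number 0.21 lower from compound 2 to compound 4 (beyond the scatter) goes beyond it. For the compounds shown here, compound 4 is drawn with no configuration at its chain carbon, and the one step beyond the scatter within the 1-phenylethyl pair rests on configuration alone: (the fact that compounds 1 and 2 differ only in the configuration as drawn).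

The compounds shown leave open how each single configuration of 1-(furan-2-yl)ethyl would read in this assay. They also leave open whether a benzyl or a 1-(thiophen-2-yl)ethyl group on this nitrogen would stand nearer compound 2 or compound 3.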